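Amide variation at the carbonyl carbon

The source may report more compounds than this note shows. Statements on the series, on what has been measured and on what is new or still open speak of the compounds shown alone.

For the measured compounds named here, compound 2 `COc1ccc(/C=C/c2cc(OC)cc(OC)c2/C=C/C(=O)N2CCN(C)CC2)cc1` stands at the lower of the two numbers so far: in a functional assay on B16-F10 cells (Mus musculus) for inhibition, read by MTT assay, with a stated time of 48 h (on this read-out higher numbers stand for weaker inhibition and lower numbers for stronger inhibition), compound 2 gives 5670 nM, and compound 1 `COc1ccc(/C=C/c2cc(OC)cc(OC)c2/C=C/C(=O)NC2CC2)cc1` gives 10200 nM. Going by the values given here, the single measured step, a 1.8-fold lower number from compound 1 to compound 2 (0.26 log units; within the scatter), lies within the scatter. Compound 3 `COc1ccc(/C=C/c2cc(OC)cc(OC)c2/C=C/C(=O)N2CCCCC2C)cc1` is yet to be measured; it differs from compound 2 by 2-methylpiperidin-1-yl in place of 4-methylpiperazin-1-yl on a carbonyl carbon. Among the compounds with values here, only the step from compound 1 to compound 2 bears on this change, and it stayed within the scatter, so no shift beyond the scatter is expected in this assay, a 1.1-fold higher number from compound 2 to compound 3 (0.02 log units; within the scatter). Compound 3 is expected near 6000 nM, within a range of 2500 nM to 15000 nM.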

Compound 3, half-maximal inhibitory concentration: 7660 nM
For compound 3 the middle estimate is 1.3-fold (0.11 log units) below the measured one; low and high end bracket the measured number.
By their numbers in this assay, from the lowest: compounds 2, 3 and 1 (each within the scatter of the next).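

In this assay, 2-methylpiperidin-1-yl in place of 4-methylpiperazin-1-yl on a carbonyl carbon gives a 1.4-fold higher number from compound 2 to compound 3 (0.13 log units; within the scatter) and stays there, while the exchange for cyclopropylamino gives a 1.3-fold lower number from compound 1 to compound 3 (0.12 log units; within the scatter) and likewise stays there. A ring carbon in place of a ring nitrogen, with the methyl moved, thus brings no shift beyond the scatter, and all three amides lie within the scatter of one another. Nothing available explains how close these numbers lie. Still open, going by these compounds, is whether a morpholin-4-yl group, an unsubstituted piperidin-1-yl group or a longer chain ending in an amine would move the number beyond the scatter.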